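One group swapped on an unmeasured antiproliferative compound

A few compounds are considered here, and "the series" means these few. Any claim that something is new, unique, unknown or untested is made for them only; others in the source may bear on it.

Measured compounds:
- compound 1 `CN1CCN(c2ccc(Nc3ncc4nc(Nc5ccc(F)cc5)n([C@@H]5CCCNC5)c4n3)cc2)CC1` – "not determined" (no result reported)
- compound 2 `CN1CCN(c2ccc(Nc3ncc4nc(Nc5ccccc5)n([C@H]5CCN(S(=O)(=O)C6CC6)C5)c4n3)cc2)CC1` – 240 nM
- compound 3 `CC(=O)Nc1cccc(-n2c(Nc3ccc(F)cc3)nc3cnc(Nc4ccc(N5CCN(C)CC5)cc4)nc32)c1` – "not determined" (no result reported)

These entries come from a functional assay on NCI-H1975 cells (Homo sapiens) for antiproliferative activity, read by MTT assay, with a stated time of 72 h (a higher number here means a weaker inhibitor, a lower number a stronger inhibitor), and give only a thin picture. Compound 3 has the entry "not determined" (no result reported), so it has no number and cannot be ranked against anything. Among the measured compounds shown here, compound 1 is in the same position, leaving compound 2 as the only compound with a number.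

The compound awaiting measurement is compound 4 `CN1CCN(c2ccc(Nc3ncc4nc(Nc5ccc(F)cc5)n([C@H]5CCN(S(=O)(=O)C6CC6)C5)c4n3)cc2)CC1`. It departs from compound 3 at a single place on the shared core: 1-(cyclopropylsulfonyl)pyrrolidin-3-yl in place of 3-acetamidophenyl on an aromatic nitrogen. In words, 1-(cyclopropylsulfonyl)pyrrolidin-3-yl stands in place of 3-acetamidophenyl on an aromatic nitrogen, while the (4-fluorophenyl)amino group stays.

With no starting number, neither a size nor a direction can be expected for this step itself. The best guide is therefore a neighbour rather than the parent. Compound 2 carries the same 1-(cyclopropylsulfonyl)pyrrolidin-3-yl group and gives 240 nM, so a result for compound 4 within the usual scatter of that value is expected. Compound 4 is estimated at 200 nM in this assay, with an expected range from 70 nM to 600 nM around that figure.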

Compound 4, half-maximal inhibitory concentration: 580 nM
Estimate against measurement, compound 4: 2.9-fold (0.46 log units) below; the measured number falls inside the stated range.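

In this assay, among the compounds shown here, the only pair that can be read keeps 1-(cyclopropylsulfonyl)pyrrolidin-3-yl on the aromatic nitrogen and changes one other place, with fluoro in place of hydrogen on an aromatic carbon, and this gives a 2.4-fold higher number from compound 2 to compound 4 (0.38 log units; beyond the scatter). With that group held fixed, a single fluoro on the phenyl ring of the amino group is enough to move the number beyond the usual scatter, towards a weaker inhibitor, so the (4-fluorophenyl)amino group is not neutral in this one pair, though a single pair sets no rule for the series. No measurement shown here gives an explanation for this shift.

On these data alone, compound 3 and compound 1 have no number, so any step from them cannot be read, and the effect of replacing 3-acetamidophenyl with 1-(cyclopropylsulfonyl)pyrrolidin-3-yl remains unknown. As far as these compounds go, it is also open whether a chloro group in place of the fluoro, or a methyl amide in place of the cyclopropylsulfonyl group on the pyrrolidine nitrogen, would move the number in the same direction or the opposite one.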